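A few compounds are considered here, and "the series" means these few. Any claim that something is new, unique, unknown or untested is made for them only; others in the source may bear on it.

Compound 1, with the structure `Cc1ccc(CNC(=O)CN(CCCCCC(=O)Nc2ccccc2N)C(=O)c2cc(C)cc(C)c2)cc1`, carries an aminophenyl amide at the end of a six-carbon chain and a 4-methylbenzyl amide on the other arm. In an assay on Sf9 cells for inhibition of protein deacetylase HDAC6 (Homo sapiens), read by fluorescence, with a stated time of 90 min (a higher number here means a weaker inhibitor, a lower number a stronger inhibitor), compound 1 gives > 10000 nM, which is a limit of the assay rather than a measured number. Compound 2, with the structure `Nc1ccccc1NC(=O)c1ccc(CN(CC(=O)NCc2ccccc2)C(=O)c2cccnc2)cc1`, was tested in the same way. In this assay compound 2 gives > 10000 nM, again only a limit. Both values therefore sit at the limit of > 10000 nM in this assay, at which 2 of the 2 values shown sit, so neither compound shows measurable inhibition here, and compound 1 cannot be placed above or below compound 2.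

Compound 3, with the structure `Cc1cc(C)cc(C(=O)N(CCCCCC(=O)Nc2ccccc2N)CC(=O)NCc2ccccc2)c1`, has not yet been measured in this assay. It differs from compound 1 by hydrogen in place of methyl on an aromatic carbon, that is, 4-methylbenzyl becomes benzyl. Within the data shown here, with compound 1 at a limit, no measured step can guide the size of this change, so the step from compound 1 to compound 3, estimated as a step that the limit leaves unreadable from compound 1 to compound 3, is expected to be small and of no clear direction beyond the scatter. Compound 3 is therefore expected to come out near 15000 nM, within a range from 5000 nM to 50000 nM.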

Compound 3, half-maximal inhibitory concentration: > 10000 nM
Compound 3: only a limit was reported; the forecaster's own chance of this, stated with the estimate: 80%; the middle value lies beyond the limit too.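

Compound 3 gives > 10000 nM in this assay, which is again a limit of the assay and not a number. No step can be read from compound 1 to compound 3, since both values are limits: the limit of > 10000 nM in this assay, at which 3 of the 3 values shown sit.

The compounds shown leave open how strongly any of them inhibits, and whether 4-methylbenzyl and benzyl differ at all.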